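A Nitro Group Joins the Hydroxy Compound

This account rests on a few compounds, and the source may have more. Where it says the series, first, only, none or still open, it means among the compounds named here.

Compound 1, `CCC[C@H](NC(=O)/C(C#N)=C/c1cccc([N+](=O)[O-])c1)c1ccccc1`, gives 1730 nM in a functional assay on MM1 cells (Homo sapiens) for antiproliferative activity, read by MTT assay, with a stated time of 72 h; on this read-out higher numbers stand for weaker inhibition and lower numbers for stronger inhibition.
Compound 2, `CCC[C@H](NC(=O)/C(C#N)=C/c1ccc(Cl)c([N+](=O)[O-])c1)c1ccccc1`, gives 1580 nM in this assay.
Compound 3, `CCC[C@H](NC(=O)/C(C#N)=C/c1ccc(O)cc1)c1ccccc1`, reaches only a limit, > 10000 nM, in this assay.

Compound 3 therefore stands at the edge of what this assay reports: it sits at the limit of > 10000 nM in this assay, at which 1 of the 3 values shown sits, and no number is known for it. Compound 4, `CCC[C@H](NC(=O)/C(C#N)=C/c1ccc(O)c([N+](=O)[O-])c1)c1ccccc1`, differs from compound 3 in one place, (nitro in place of hydrogen on an aromatic carbon).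

Going by the values given here, the single measured step, a 1.1-fold lower number from compound 1 to compound 2 (0.04 log units; within the scatter), concerns a chloro group entering a ring that already carries the nitro group, and it stays within the scatter; it says nothing directly about a nitro group entering next to a hydroxy-bearing ring. What the data do show is that compound 1, which carries the nitro group and no hydroxy group, gives 1730 nM in this assay. Compound 3, with the hydroxy group and no nitro group, reaches only the limit. Compound 4 carries both groups, so its number is expected to come down from the limit, with an expected step of an at least 2.0-fold lower number from compound 3 to compound 4 (0.30 log units; that floor lies within the scatter), though the starting point is only a bound. For compound 4 the expected value in this assay is 5000 nM, with a range from 1500 nM to 20000 nM.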

Compound 4, half-maximal inhibitory concentration: 8200 nM
The estimate for compound 4 lay 1.6-fold (0.21 log units) below the measured number; measured number inside the range.
By their numbers in this assay, from the lowest: compounds 2 and 1 (each within the scatter of the next); then compound 4. At a limit, above all of these: compound 3.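

Going by these compounds alone, compound 4 is the first compound here with a hydroxy group to give a number rather than a limit in this assay, with the nitro group sitting ortho to that hydroxy group, yet the step reads only as a floor: an at least 1.2-fold lower number from compound 3 to compound 4 (0.08 log units; that floor lies within the scatter). Compound 3 remains at a limit: the limit of > 10000 nM in this assay, at which 1 of the 4 values shown sits. Among the compounds that carry the nitro group, the hydroxy group goes with weaker inhibition, both in place of chloro, a 5.2-fold higher number from compound 2 to compound 4 (0.72 log units; beyond the scatter), and in place of hydrogen, a 4.7-fold higher number from compound 1 to compound 4 (0.68 log units; beyond the scatter).

From the compounds shown here alone, the true size of the nitro step stays open, as does whether it is any larger than the usual scatter, for compound 3 has no number to start from. The compounds shown also leave open whether an amine or a methoxy group in place of the hydroxy group, with the nitro group kept, would return the number to where compound 1 and compound 2 stand.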